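The source may hold more compounds than are shown below. What is called first, only, known or untested is meant among the compounds shown, and "the series" means these compounds.

Working notes on the series, read in a functional assay on MCF7 cells (Homo sapiens) for inhibition, read by sulforhodamine B assay; a higher number here means a weaker inhibitor, a lower number a stronger inhibitor. Compound 1 `O=C1C=C(NCc2ccccc2)C(=O)c2c1nc1n2[C@H]2OC[C@@H](O)[C@H]2OC1` carries a benzyl group on an amine nitrogen, and it has no number in this read-out, only a limit: compound 1 gives > 8000 nM. Compound 2 `O=C1C(NC2CCCC2)=CC(=O)c2c1nc1n2[C@H]2OC[C@@H](O)[C@H]2OC1` also has only a limit, as compound 2 gives > 16000 nM. No order can be read between these two results, and compound 1 has no exact place on the scale.

Compound 3 `O=C1C=C(Nc2cccc(F)c2)C(=O)c2c1nc1n2[C@H]2OC[C@@H](O)[C@H]2OC1` has not yet been measured in this assay. It has 3-fluorophenyl in place of benzyl on an amine nitrogen. Going by the values given here, no measured pair shows what this swap does, so the expectation rests only on the limit of compound 1 at > 8000 nM. No step beyond the usual scatter is expected, in either direction, and another limit instead of a number is quite possible. The expected step is an at least 1.1-fold lower number from compound 1 to compound 3 (0.05 log units; that floor lies within the scatter). For compound 3 the estimated value is 7000 nM, with an expected range from 2000 nM to 25000 nM.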

Compound 3, half-maximal inhibitory concentration: 5500 nM
Beside the measured number, compound 3's estimate is 1.3-fold (0.10 log units) above it; low and high end bracket the measured number.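

In this assay, going by these compounds alone, compound 3 gives 5500 nM, the first exact number, with 3-fluorophenyl in place of benzyl on the amine nitrogen. The swap reads as an at least 1.4-fold lower number from compound 1 to compound 3 (0.16 log units; that floor lies within the scatter), which gives a floor for the change at this position and not its size, so no gain beyond the scatter is established. The true size of the step stays unknown because the value of compound 1 is only a limit: the limit of > 8000 nM in this assay, at which 1 of the 3 values shown sits.

The compounds shown leave open how much of the step goes with the fluorine and how much with the change from benzyl to a ring set directly on the amine nitrogen; an unsubstituted phenyl or a 3-fluorobenzyl group at the same place would separate the two. Also open, from the compounds shown here alone, is whether other groups on that nitrogen, such as a morpholine-bearing ethyl chain or a longer alkyl chain, would give an exact number in this assay at all.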